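A few compounds are considered here, and "the series" means these few. Any claim that something is new, unique, unknown or untested is made for them only; others in the source may bear on it.

Of the compounds shown here, three have been measured in a functional assay on A549 cells (Homo sapiens) for inhibition, read by MTT assay, with a stated time of 48 h; a lower number here means a stronger inhibitor, a higher number a weaker inhibitor. Compound 1 `CCC(C)NC(=O)/C=C/c1c(/C=C/c2ccc(OC)cc2)cc(OC)cc1OC` gives 3950 nM, and compound 2 `COc1ccc(/C=C/c2cc(OC)cc(OC)c2/C=C/C(=O)Nc2cc(OC)c(OC)c(OC)c2)cc1` gives 5140 nM. Compound 3 `COc1ccc(/C=C/c2cc(OC)cc(OC)c2/C=C/C(=O)NC(C)C)cc1` stands lowest of the three in this assay, where compound 3 gives 2360 nM. The step of a 1.7-fold lower number from compound 1 to compound 3 (0.22 log units; within the scatter) lies within the scatter, while the step of a 2.2-fold lower number from compound 2 to compound 3 (0.34 log units; beyond the scatter) is modest but beyond it.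

Compound 4 `COc1ccc(/C=C/c2cc(OC)cc(OC)c2/C=C/C(=O)N2CCCC(C)C2)cc1` differs from compound 3 by 3-methylpiperidin-1-yl in place of isopropylamino on a carbonyl carbon. The two measured steps that alter the group on the amide-type nitrogen bear on this change, namely a 1.7-fold lower number from compound 1 to compound 3 (0.22 log units; within the scatter) and a 2.2-fold lower number from compound 2 to compound 3 (0.34 log units; beyond the scatter), and neither is large. For the measured compounds named here, no measured step replaces the amide hydrogen with a ring, so the direction of this move is not anchored by the data, and a step of comparable size, or none beyond the scatter, is expected in this assay. Compound 4 is therefore expected to come in near 3000 nM, within a range from 1200 nM to 8000 nM. The expected step is a 1.3-fold higher number from compound 3 to compound 4 (0.10 log units; within the scatter).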

Compound 4, half-maximal inhibitory concentration: 5820 nM
The estimate for compound 4 lay 1.9-fold (0.29 log units) below the measured number; measured number inside the range.
By their numbers in this assay, from the lowest: compounds 3, 1, 2 and 4 (each within the scatter of the next, the first and the last beyond it).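

Among the compounds shown, only compound 4 lacks the amide hydrogen, and in this assay replacing isopropylamino on this carbonyl carbon with 3-methylpiperidin-1-yl gives a 2.5-fold higher number from compound 3 to compound 4 (0.39 log units; beyond the scatter). Replacing (sec-butyl)amino with the same ring gives a 1.5-fold higher number from compound 1 to compound 4 (0.17 log units; within the scatter), so the change stands beyond the scatter against only one of these two amine groups. No measurement at hand accounts for this step.

The compounds shown leave open whether the step goes with the loss of the amide hydrogen, with the ring or with its methyl group. From the compounds shown here alone, it also remains open whether a piperidin-1-yl group without the methyl, a morpholin-4-yl group or a dimethylamino group on the same carbonyl carbon would give a number nearer that of compound 3 or that of compound 4.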